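Para-substituent swap in the triazolylmethyl amide series

The source may report more compounds than this note shows. Statements on the series, on what has been measured and on what is new or still open speak of the compounds shown alone.

Compound 2 `CC(C)n1ncc2c(C(=O)NCc3cn(-c4ccc([N+](=O)[O-])cc4)nn3)cccc21` is the starting point of this step. In a functional assay on PC-3 cells (Homo sapiens) for inhibition, read by MTT assay, with a stated time of 72 h (a higher number here means a weaker inhibitor, a lower number a stronger inhibitor), compound 2 gives > 40000 nM, which is a limit of the assay and not a number. Compound 1 `CC(C)n1ncc2c(C(=O)NCc3cn(-c4ccc(I)cc4)nn3)cccc21` carries iodo where compound 2 carries nitro. In this assay compound 1 gives > 40000 nM, again a limit only. Within the data shown here, the single measured step, a step that the two limits leave unreadable from compound 1 to compound 2, cannot be sized, and both values sit at the limit of > 40000 nM in this assay, at which 2 of the 2 values shown sit. Compound 3 `CC(C)n1ncc2c(C(=O)NCc3cn(-c4ccc(C(F)(F)F)cc4)nn3)cccc21` differs from compound 2 by trifluoromethyl in place of nitro on an aromatic carbon. Among the measured compounds shown here, no measured step bears on this change with a readable size, so neither direction can be drawn from the series. The expectation is that compound 3 remains at the limit, and the step that the limit leaves unreadable from compound 2 to compound 3 is expected to be without readable size. Compound 3 is estimated at 60000 nM, with a range from 15000 nM to 250000 nM.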

Compound 3, half-maximal inhibitory concentration: 38600 nM
The estimate for compound 3 lay 1.6-fold (0.19 log units) above the measured number, and the stated range covers the measured number.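

Among these compounds, with trifluoromethyl on this aromatic carbon, para to a large group, the series gains its only value that is a number and not a limit of the assay: in this assay compound 3 gives 38600 nM. The change from nitro gives an at least 1.0-fold lower number from compound 2 to compound 3 (0.01 log units; that floor lies within the scatter), and the change from iodo gives an at least 1.0-fold lower number from compound 1 to compound 3 (0.01 log units; that floor lies within the scatter); both are floors within the scatter, so no order among the three groups can be drawn. The step between the other two compounds still cannot be read: the limit of > 40000 nM in this assay, at which 2 of the 3 values shown sit.

On these data alone, how far compound 1 and compound 2 actually lie from compound 3 remains open. Also open, as far as these compounds go, is what an amine, a carboxylic acid or a longer alkyl chain would give at this position on the 4-substituted phenyl ring.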